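The source may report more compounds than this note shows. Statements on the series, on what has been measured and on what is new or still open speak of the compounds shown alone.

Measured so far:
- Compound 1, `S=c1oc(-c2ccc3c(c2)OCCO3)nn1CN1CCN(c2cccc(Cl)c2Cl)CC1`: in a functional assay on HepG2 cells (Homo sapiens) for antiproliferative activity, read by MTT assay, with a stated time of 48 h (a lower number here means a stronger inhibitor, a higher number a weaker inhibitor), compound 1 gives > 50000 nM, which is a limit of the assay.
- Compound 2, `S=c1oc(-c2ccc3c(c2)OCCO3)nn1CN1CCN(c2ccccc2)CC1`: in this assay compound 2 gives > 50000 nM, likewise a limit of the assay.

Compound 2 thus stands at the limit of > 50000 nM in this assay, at which 2 of the 2 values shown sit, with no number of its own. For the measured compounds named here, the single measured step, a step that the two limits leave unreadable from compound 1 to compound 2, is unreadable, so it gives no size to carry over. Compound 3, `Fc1ccc(N2CCN(Cn3nc(-c4ccc5c(c4)OCCO5)oc3=S)CC2)cc1`, differs from compound 2 by fluoro in place of hydrogen on an aromatic carbon. Compound 3 is expected to remain at the limit in this assay, with an estimated 50000 nM spanning 20000 nM to 120000 nM and an expected step of a number no higher from compound 2 to compound 3 (the limit leaves the size open) within scatter.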

Compound 3, half-maximal inhibitory concentration: > 50000 nM
Compound 3: a limit, no number (the forecaster's own chance of this, stated with the estimate: 85%); the middle value sits exactly at the limit.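

In this assay compound 3 gives > 50000 nM, a limit of the assay. No step among compound 1, compound 2 and compound 3 can be read: the limit of > 50000 nM in this assay, at which 3 of the 3 values shown sit.

Left open is whether any compound of this series reaches a measurable value in this assay.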